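Methyl for cyclopropyl on the piperazine amine

The source may hold more compounds than are shown below. What is called first, only, known or untested is meant among the compounds shown, and "the series" means these compounds.

Compounds measured so far in an ADME assay on microsomes from liver (Mus musculus) for metabolic stability, read by LC-MS, with a stated time of 10 min, tested at 0.5 uM (on this read-out higher numbers stand for a more stable compound and lower numbers for a less stable compound), are:
- compound 1 `c1ccc2c(c1)CN[C@@H](CN(CC1CCNCC1)[C@H]1CCCc3cccnc31)C2` with 13%
- compound 2 `c1ccc2c(c1)CN[C@@H](CN(CCN1CCNCC1)[C@H]1CCCc3cccnc31)C2` with 79%
- compound 3 `c1ccc2c(c1)CN[C@@H](CN(CCCN1CCN(C3CC3)CC1)[C@H]1CCCc3cccnc31)C2` with 3%

Compound 3 sits at the low end with compound 1, within the scatter of it, and far under compound 2. Compound 4 `CN1CCN(CCCN(C[C@H]2Cc3ccccc3CN2)[C@H]2CCCc3cccnc32)CC1` differs from compound 3 in one place: methyl in place of cyclopropyl on an amine nitrogen in a ring. Among the measured compounds shown here, no measured step makes this swap alone. The nearest evidence is the large step of a number 76 percentage points lower from compound 2 to compound 3 (beyond the scatter) (which also alters the chain), so only a part of it should carry over. A small rise in this assay is expected, with a number 11 percentage points higher from compound 3 to compound 4 (beyond the scatter) as the estimated step. Compound 4 is estimated at 14% with 3% to 40% as the expected range.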

Compound 4, percent of the compound remaining: 53%
The estimate for compound 4 lay 39 percentage points below the measured number, outside the stated range (above it).
By their numbers in this assay, from the lowest: compounds 3 and 1 (each within the scatter of the next); then compound 4; then compound 2.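

In this assay, methyl in place of cyclopropyl on an amine nitrogen in a ring gives a number 50 percentage points higher from compound 3 to compound 4 (beyond the scatter), so this one substituent alone separates a low number from a middling one, with the chain unchanged. Compound 4 also stands apart from the piperidine series, with a number 40 percentage points higher from compound 1 to compound 4 (beyond the scatter), yet it does not reach the piperazine with the shorter chain, with a number 26 percentage points lower from compound 2 to compound 4 (beyond the scatter), though both steps alter more than this substituent. Nothing available explains the size of the methyl effect. On these data alone, it remains open where ethyl or isopropyl on this nitrogen would fall, and what the unsubstituted piperazine amine would give on the chain of compound 4.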